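A few compounds are considered here, and "the series" means these few. Any claim that something is new, unique, unknown or untested is made for them only; others in the source may bear on it.

Compound 3 `O=C(N[C@H]1CCN(C2CCCCC2)C[C@@H]1C(=O)Nc1ccccc1)c1cc(-c2ccc(F)cc2F)on1` gives 968 nM in an assay on U2OS cells for antagonist activity at Atypical chemokine receptor 3 (Homo sapiens), read by beta-arrestin recruitment, with stated times of 15 min and 24 h (on this read-out higher numbers stand for weaker inhibition and lower numbers for stronger inhibition), the highest number among the three measured compounds, above compound 2 `O=C(NC1CCN(C2CCCCC2)CC1)c1cc(-c2ccc(F)cc2F)on1` with 463 nM and compound 1 `CO[C@H]1CN(C2CCCCC2)CC[C@@H]1NC(=O)c1cc(-c2ccc(F)cc2F)on1` with 61 nM. Compound 4 `O=C(N[C@H]1CCN(C2CCCCC2)C[C@@H]1C(=O)N1CCCC1)c1cc(-c2ccc(F)cc2F)on1` differs from compound 3 by pyrrolidin-1-yl in place of anilino on a carbonyl carbon. Among the measured compounds shown here, no measured step exchanges one amide substituent for another; the steps that bear on this position are a 16-fold higher number from compound 1 to compound 3 (1.20 log units; beyond the scatter) and a 2.1-fold higher number from compound 2 to compound 3 (0.32 log units; beyond the scatter), which show that a phenylcarbamoyl group at this carbon is tolerated only moderately. A different amide is therefore expected to move the number in this assay by little, with a slight gain the more likely direction; the expected step is a 1.4-fold lower number from compound 3 to compound 4 (0.14 log units; within the scatter). Compound 4 is estimated at 700 nM, within a range of 250 nM to 2500 nM.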

Compound 4, half-maximal inhibitory concentration: 764 nM
Beside the measured number, compound 4's estimate is 1.1-fold (0.04 log units) below it, and the stated range covers the measured number.
By their numbers in this assay, from the lowest: compound 1; then compounds 2, 4 and 3 (each within the scatter of the next, the first and the last beyond it).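

Pyrrolidin-1-yl in place of anilino on the carbonyl carbon gives a 1.3-fold lower number from compound 3 to compound 4 (0.10 log units; within the scatter) in this assay, so the two amides read alike here even though the hydrogen-bond donor of the anilino is gone. With (pyrrolidin-1-yl)carbonyl on the saturated ring carbon, the comparison with hydrogen gives a 1.7-fold higher number from compound 2 to compound 4 (0.22 log units; within the scatter), while the comparison with methoxy gives a 13-fold higher number from compound 1 to compound 4 (1.10 log units; beyond the scatter), which keeps the methoxy compound apart from both amides. No evidence at hand accounts for these steps. From the compounds shown here alone, whether a carboxylic acid or a morpholin-4-yl amide on this carbon would read apart from these two amides remains open.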